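Hydroxyphenyl placement on the trifluoromethoxy member of the series

The compounds below may be only part of what the source reports. "The series", "measured", "known", "first", "only" and "open" are said of these compounds alone.

Compound 3 `Oc1ccc(-c2cc(-c3cccc(OC(F)(F)F)c3)cc(-c3ccccc3O)n2)cc1` is one of the two members of this set for which a functional assay on HeLa cells (Homo sapiens) for inhibition (on this read-out lower numbers stand for stronger inhibition and higher numbers for weaker inhibition), returns only a limit. In this assay compound 3 gives > 50000 nM, which is a limit of the assay and not a number. The same holds for compound 1 `Oc1ccc(-c2cc(-c3cccc(C(F)(F)F)c3)cc(-c3ccccc3O)n2)cc1`, which in this assay gives > 50000 nM, again a limit. Within the data shown here, compound 2 `Oc1ccc(-c2cc(-c3cccc(C(F)(F)F)c3)cc(-c3cccc(O)c3)n2)cc1` is the only member with a read number, and in this assay compound 2 gives 16200 nM. The step that the two limits leave unreadable from compound 1 to compound 3 cannot be sized because the limit of > 50000 nM in this assay, at which 2 of the 3 values shown sit, sits at both of its ends.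

Compound 4 `Oc1ccc(-c2cc(-c3cccc(OC(F)(F)F)c3)cc(-c3cccc(O)c3)n2)cc1` differs from compound 3 in one place: 3-hydroxyphenyl in place of 2-hydroxyphenyl on an aromatic carbon. The same exchange has been measured once in this series, as an at least 3.0-fold lower number from compound 1 to compound 2 (0.48 log units; beyond the scatter), where the starting point was likewise a limit. On that basis the step to compound 4 is expected to be a lowering of comparable size, though a single precedent that starts from a limit leaves the true extent open. For compound 4 an estimate of 18000 nM is taken, with a range from 6000 nM to 50000 nM. This corresponds to an expected step of an at least 2.7-fold lower number from compound 3 to compound 4 (0.44 log units; beyond the scatter), while a result that again reaches only the limit remains a real possibility.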

Compound 4, half-maximal inhibitory concentration: 14100 nM
Beside the measured number, compound 4's estimate is 1.3-fold (0.11 log units) above it, within the range that was stated.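

The change from 2-hydroxyphenyl to 3-hydroxyphenyl, on the aromatic carbon next to the ring nitrogen, now has a second read in this assay, and the lowering is no longer tied to the trifluoromethyl member, with an at least 3.5-fold lower number from compound 3 to compound 4 (0.54 log units; beyond the scatter). Taken together, the two cores give the following picture: the same change on two cores in this assay, an at least 3.0-fold lower number (0.48 log units; beyond the scatter) from compound 1 to compound 2 and an at least 3.5-fold lower number (0.54 log units; beyond the scatter) from compound 3 to compound 4; the limit leaves it open whether they differ

Among these compounds, with 3-hydroxyphenyl in place, the exchange of trifluoromethyl for trifluoromethoxy can be read for the first time, as a 1.1-fold lower number from compound 2 to compound 4 (0.06 log units; within the scatter), so on this pair the two groups are not told apart by this read-out. With 2-hydroxyphenyl in place, the same exchange cannot be read, and both hydroxyphenyl steps remain bounds rather than sizes: the limit of > 50000 nM in this assay, at which 2 of the 4 values shown sit.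

Still open, going by these compounds, is whether the hydroxyl of the 3-hydroxyphenyl group itself matters, which a 3-methoxyphenyl or 3-aminophenyl group on the same carbon would test. Also open, on these data alone, is whether a carboxylic acid or a nitrile in place of trifluoromethoxy would shift the value of compound 4, given that trifluoromethyl and trifluoromethoxy stay within the scatter of each other.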